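A few compounds are considered here, and "the series" means these few. Any claim that something is new, unique, unknown or untested is made for them only; others in the source may bear on it.

Three compounds share a core carrying a urea that joins an isopropyl-triazolyl-substituted pyridine to a varying heteroaromatic group. In an assay on isolated protein for inhibition of mitogen-activated protein kinase kinase kinase 6 (Homo sapiens) (a lower number here means a stronger inhibitor, a higher number a weaker inhibitor), compound 1 `CC(C)n1cnnc1-c1cccc(NC(=O)Nc2ccc(-c3ccn(C)n3)cn2)n1` gives 2780 nM, compound 2 `CC(C)n1cnnc1-c1cccc(NC(=O)Nc2cnc3ccccc3n2)n1` gives 4860 nM, and compound 3 `CC(C)n1cnnc1-c1cccc(NC(=O)Nc2ncc3[nH]cnc3n2)n1` gives 742 nM. The number for compound 2 stands at the top of the three, but compound 1 sits within the usual scatter of it, while compound 3 lies beyond the scatter with a clearly lower number, so only compound 3 is separated from compound 2 by more than measurement noise.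

Compound 4 `C[C@H](CO)n1cnnc1-c1cccc(NC(=O)Nc2cnc3ccccc3n2)n1` keeps the heteroaromatic group of compound 2 and differs from it in one place: hydroxy in place of hydrogen on a saturated chain carbon, two bonds along the chain from an aromatic nitrogen, which reads, cut one bond further out, as isopropyl to 1-(hydroxymethyl)ethyl. Among the measured compounds shown here, no measured pair in this set shows the effect of such a change, so there is nothing to anchor its direction. The step from compound 2 to compound 4 in this assay is expected to be small, with no change beyond the scatter, as a 1.2-fold lower number from compound 2 to compound 4 (0.06 log units; within the scatter) expresses. Compound 4 is therefore estimated to give 4200 nM in this assay, within a range of 1500 nM to 12000 nM.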

Compound 4, half-maximal inhibitory concentration: > 10000 nM
Compound 4 gave a limit, no number; the forecaster's own chance of this, stated with the estimate: 10%; middle value at least 2.3-fold (0.37 log units) from the limit.
By their numbers in this assay, from the lowest: compound 3; then compounds 1 and 2 (each within the scatter of the next). At a limit, above all of these: compound 4.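

With hydroxy in place of hydrogen on a saturated chain carbon, two bonds along the chain from an aromatic nitrogen, this position gives its first readable step in this assay, and that step goes towards a higher number: an at least 2.0-fold higher number from compound 2 to compound 4 (0.31 log units; beyond the scatter). Compound 4 gives > 10000 nM, which is a limit of the assay and not a number. The change from isopropyl to 1-(hydroxymethyl)ethyl therefore weakens inhibition beyond the scatter on the background of compound 2, but the reading fixes only a lower bound on the size of the step: the limit of > 10000 nM in this assay, at which 1 of the 4 values shown sits.

The same change is shown only with the heteroaromatic group of compound 2, so its effect with the groups of compound 1 or compound 3 remains open. Also open, going by these compounds, is how an amine, a methoxy group or a carboxylic acid in place of the hydroxy, or a longer chain carrying the hydroxy, would read in this assay.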